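Swapping the Dienyl Amide Chain for a Selenium-Bearing Group

The source may hold more compounds than are shown below. What is called first, only, known or untested is meant among the compounds shown, and "the series" means these compounds.

Compound 1 `COc1ccc(CNc2cc(OC)c(OC)c(OC)c2)cc1C`: 56800 nM
Compound 2 `C/C=C/C=C/C(=O)N(Cc1ccc(OC)c(O)c1)c1cc(OC)c(OC)c(OC)c1`: 140 nM

In a functional assay on MGC-803 cells (Homo sapiens) for inhibition, read by MTT assay, with a stated time of 48 h (on this read-out lower numbers stand for stronger inhibition and higher numbers for weaker inhibition), compound 2 gives the lowest of the two numbers, and compound 1 sits far higher, a gap well beyond the usual scatter. Compound 3 `COc1ccc(CN(C(=O)C[Se]C#N)c2cc(OC)c(OC)c(OC)c2)cc1O` keeps the amide of compound 2 but changes what hangs on its carbonyl carbon: a group of 4 heavy atoms (2 carbon, 1 nitrogen, 1 selenium; no ring) in place of a group of 5 heavy atoms (5 carbon; no ring), on a carbonyl carbon. Among the compounds with values here, with no measured pair isolating this change, a moderate loss is expected, a 4.3-fold higher number from compound 2 to compound 3 (0.63 log units; beyond the scatter), because the low number of compound 2, 140 nM, is the only potency seen with an acyl group present. Compound 3 is estimated at 600 nM, within 120 nM to 3000 nM.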

Compound 3, half-maximal inhibitory concentration: 270 nM
The estimate for compound 3 lay 2.2-fold (0.35 log units) above the measured number; low and high end bracket the measured number.
By their numbers in this assay, from the lowest: compounds 2 and 3 (each within the scatter of the next); then compound 1.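

In this assay, placing the selenium-bearing group on the carbonyl carbon gives a 1.9-fold higher number from compound 2 to compound 3 (0.29 log units; within the scatter), so the penta-1,3-dien-1-yl chain is not needed for a number in this range. At this position, a group with two double bonds and one with a triple bond and selenium read alike, at least for this pair. No measured evidence here explains this result. From the compounds shown here alone, it remains open how much the selenium and the nitrile each contribute. A sulfur atom in place of selenium, a plain methyl group, or a longer saturated chain on the carbonyl carbon could separate these parts.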